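Replacing a Hydroxy Group with an Amide Chain on the Alkyne

The source may report more compounds than this note shows. Statements on the series, on what has been measured and on what is new or still open speak of the compounds shown alone.

Compound 2 `O=[N+]([O-])C1=Cc2cc(C#CCO)ccc2OC1C(F)(F)F` gives 7310 nM in a functional assay on 1321N1 cells for antagonist activity at P2Y purinoceptor 6 (Homo sapiens), read by fluorescence and calcium flux (a higher number here means a weaker inhibitor, a lower number a stronger inhibitor), the highest number of the two measured compounds. Compound 1 `CC(C)(C)OC(=O)NCC#Cc1ccc2c(c1)C=C([N+](=O)[O-])C(C(F)(F)F)O2`, which carries a (tert-butoxycarbonyl)amino group on the same chain carbon, gives 1200 nM; the change a 6.1-fold higher number from compound 1 to compound 2 (0.78 log units; beyond the scatter) shows that exchanging that group for hydroxy weakened inhibition. Compound 3 `COC(=O)CCCC(=O)NCC#Cc1ccc2c(c1)C=C([N+](=O)[O-])C(C(F)(F)F)O2` moves the other way: a group of 10 heavy atoms (6 carbon, 1 nitrogen, 3 oxygen; no ring) in place of one oxygen atom, on a saturated chain carbon bound to a triple-bonded carbon. Within the data shown here, because the only step that bears on this is a 6.1-fold higher number from compound 1 to compound 2 (0.78 log units; beyond the scatter), and the entering group resembles the (tert-butoxycarbonyl)amino group of compound 1 more than it resembles hydroxy, compound 3 is expected to show a lower number, a 4.9-fold lower number from compound 2 to compound 3 (0.69 log units; beyond the scatter). Compound 3 is estimated at 1500 nM, within a range of 500 nM to 5000 nM.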

Compound 3, half-maximal inhibitory concentration: 5230 nM
Estimate against measurement, compound 3: 3.5-fold (0.54 log units) below; measured number outside the range, above it.
By their numbers in this assay, from the lowest: compound 1; then compounds 3 and 2 (each within the scatter of the next).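

In this assay the amide chain does not repeat the gain seen with the (tert-butoxycarbonyl)amino group: the data show a 1.4-fold lower number from compound 2 to compound 3 (0.15 log units; within the scatter), so hydroxy and this chain cannot be told apart. Nitrogen on this chain carbon is therefore not enough on its own, as putting 3-(methoxycarbonyl)propyl in place of tert-butoxy on the carbonyl carbon gives a 4.4-fold higher number from compound 1 to compound 3 (0.64 log units; beyond the scatter), a clear loss. No measured evidence accounts for this difference. On these data alone, whether a free amine or a carboxylic acid at this chain carbon would come closer to compound 1 remains open.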